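Exchanging Chlorine for an Amine on the Acetamide Chain

A few compounds are considered here, and "the series" means these few. Any claim that something is new, unique, unknown or untested is made for them only; others in the source may bear on it.

In a functional assay for inhibition, with Homo sapiens as the target (a higher number here means that more compound is needed for the effect, a lower number that less compound is needed), compound 1 `Nc1ccc(C2=NNC(=O)CC2)cc1` gives 46.4 ug/mL. Compound 2 `O=CNc1ccc(C2=NNC(=O)CC2)cc1` gives 3.74 ug/mL in this assay, and compound 3 `O=C1CCC(c2ccc(NC(=O)CCl)cc2)=NN1` gives 0.39 ug/mL, the lowest of the three numbers, with compound 2 nearest to it and compound 1 furthest away. The measured steps are large: a 12-fold lower number from compound 1 to compound 2 (1.09 log units; beyond the scatter), a 120-fold lower number from compound 1 to compound 3 (2.08 log units; beyond the scatter) and a 9.6-fold lower number from compound 2 to compound 3 (0.98 log units; beyond the scatter).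

Compound 4 `CCC(C)NCC(=O)Nc1ccc(C2=NNC(=O)CC2)cc1` differs from compound 3 in a single place: (sec-butyl)amino in place of chloro on a saturated chain carbon bound to a carbonyl carbon. Within the data shown here, none of the measured steps alters a group on a saturated chain carbon bound to a carbonyl carbon; the three steps only add a formyl or (chloromethyl)carbonyl group on the nitrogen on the aromatic ring, or chloromethyl on the carbonyl carbon. The step of a 9.6-fold lower number from compound 2 to compound 3 (0.98 log units; beyond the scatter) shows that what sits on that carbonyl carbon moves the number strongly, so swapping chloro for (sec-butyl)amino is expected to change the number beyond the scatter, most likely upward, as a 6.4-fold higher number from compound 3 to compound 4 (0.81 log units; beyond the scatter). Compound 4 is therefore estimated at 2.5 ug/mL, within the range 0.5 ug/mL to 12 ug/mL.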

Compound 4, half-maximal effective concentration: about 21.5 ug/mL
For compound 4 the middle estimate is 8.6-fold (0.93 log units) below the measured one; the measured number lies above the stated range.
By their numbers in this assay, from the lowest: compound 3; then compound 2; then compound 4; then compound 1.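

Among these compounds, this is the first change at the saturated chain carbon bound to a carbonyl carbon, and in this assay it is a large one: (sec-butyl)amino in place of chloro gives a 55-fold higher number from compound 3 to compound 4 (1.74 log units; beyond the scatter) in this series. The ((sec-butyl)amino)methyl group also compares poorly with the bare hydrogen on the carbonyl carbon, with a 5.7-fold higher number from compound 2 to compound 4 (0.76 log units; beyond the scatter) as the step, so a group on that carbon can raise the number as well as lower it, as chloromethyl does in compound 3. No measurement shown here accounts for the difference between chloro and (sec-butyl)amino.

From the compounds shown here alone, it remains open whether the higher number goes with the nitrogen itself or with the sec-butyl group on it, which a plain amino, a dimethylamino or a piperidine group at this place could separate. Bromo or methoxy in place of chloro could likewise show how much depends on chlorine itself.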